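The compounds below may be only part of what the source reports. "The series", "measured", "known", "first", "only" and "open" are said of these compounds alone.

Two members of the series carry a measurement in a functional assay on Ehrlich cells (Mus musculus) for cytotoxicity, read by trypan blue exclusion, with a stated time of 2 h, tested at 50 ug/mL; on this read-out lower numbers stand for a weaker effect and higher numbers for a stronger effect at the one concentration tested. Compound 1 `Cc1ccc(C2C(C#N)=C(N)N(c3ccc(S(N)(=O)=O)cc3)C3=C2CCCC3)cc1` gives 80% and stands highest of the two numbers; compound 2 `N#CC1=C(N)N(c2ccc(S(N)(=O)=O)cc2)C2=C(CCCC2)C1c1ccccc1Cl` gives 5%. Within the data shown here, the only measured step, a number 75 percentage points lower from compound 1 to compound 2 (beyond the scatter), puts 2-chlorophenyl in place of 4-methylphenyl on a saturated ring carbon and is large. Compound 3 `N#CC1=C(N)N(c2ccc(S(N)(=O)=O)cc2)C2=C(CCCC2)C1c1c(O)ccc2ccccc12` is not yet measured in this assay; it differs from compound 1 on that same saturated ring carbon: 2-hydroxynaphthalen-1-yl in place of 4-methylphenyl on a saturated ring carbon. Among the measured compounds shown here, the one step that bears on this change is a number 75 percentage points lower from compound 1 to compound 2 (beyond the scatter), so a second exchange of the group on that carbon is expected to lower the number as well, though the entering group is a different one and the size of the drop is uncertain. Compound 3 is therefore expected to give 25% in this assay, within 5% to 65%, which means an expected step of a number 55 percentage points lower from compound 1 to compound 3 (beyond the scatter).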

Compound 3, a percentage reported as activity, at one concentration (the size of the read-out at that concentration, not a potency): 20%
Estimate against measurement, compound 3: 5 percentage points above; the measured number falls inside the stated range.
By their numbers in this assay, from the lowest: compound 2; then compound 3; then compound 1.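

In this assay, a second replacement of 4-methylphenyl on this saturated ring carbon also brings a large drop, a number 60 percentage points lower from compound 1 to compound 3 (beyond the scatter), so among the three groups shown, only 4-methylphenyl gives a high number. The loss therefore is not confined to 2-chlorophenyl: it also appears with 2-hydroxynaphthalen-1-yl, which has two six-membered aromatic rings of carbon only and a hydrogen-bond donor. The two low compounds are still separated, by a number 15 percentage points higher from compound 2 to compound 3 (beyond the scatter), so the position distinguishes between these replacements too, but no measurement at hand gives a reason for either step.

Open, from the compounds shown here alone, is whether the high number depends on the methyl group, or whether phenyl, 4-chlorophenyl or 4-methoxyphenyl on this carbon would retain it. Also open, going by these compounds, is whether the ranking of these groups would hold with a group other than the cyano group on the neighbouring ring atom, such as a carboxylic acid.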